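Working notes: phenyl to 3,5-difluorophenyl on the shared core

This account rests on a few compounds, and the source may have more. Where it says the series, first, only, none or still open, it means among the compounds named here.

Measured compounds:
compound 1, `C[C@H](Nc1nc(N)nc(N)c1C#N)c1cc(=O)n2cc(F)ccc2c1-c1ccccc1`: "not determined" (no result reported)
compound 2, `C[C@H](Nc1ncnc(N)c1C#N)c1cc(=O)n2cc(F)ccc2c1-c1ccccc1`: 90%

In an ADME assay on microsomes from liver (Homo sapiens), read by LC-MS, using NADPH, with a stated time of 30 min, tested at 1 uM (a higher number here means that more of the compound is left, a lower number that less of the compound is left), compound 1 stands nowhere on the numbers: no result is reported. Among the measured compounds shown here, the only anchor is compound 2, which in this assay gives 90%. Compound 3, `C[C@H](Nc1nc(N)nc(N)c1C#N)c1cc(=O)n2cc(F)ccc2c1-c1cc(F)cc(F)c1`, carries the change 3,5-difluorophenyl in place of phenyl on an aromatic carbon relative to compound 1. For the measured compounds named here, no step is known for this pair, and without a value for compound 1 no direction can be read off; the expected shift in this assay is small, likely within the usual scatter. Compound 3 is estimated at 82%, with a range from 60% to 100%.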

Compound 3, percent of the compound remaining: 94%
The estimate for compound 3 lay 12 percentage points below the measured number; measured number inside the range.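

In this assay compound 1 reads "not determined" (no result reported) while compound 3 gives 94% so no step can be read for this pair. The compounds shown leave open what 3,5-difluorophenyl in place of phenyl does to the percent remaining on the shared core. No evidence bears on this result.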